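Taking the methoxy group off compound 3

This account rests on a few compounds, and the source may have more. Where it says the series, first, only, none or still open, it means among the compounds named here.

In a functional assay on HUVEC cells (Homo sapiens) for antiproliferative activity, read by MTT assay, with a stated time of 48 h (a lower number here means a stronger inhibitor, a higher number a weaker inhibitor), compound 1 `Fc1ccc(/C=C/c2nnc(-c3ccc4c(c3)OCCO4)o2)cc1` gives 4960 nM. Compound 2 `Clc1ccccc1/C=C/c1nnc(-c2ccc3c(c2)OCCO3)o1` gives 7710 nM. These two are separated by a 1.6-fold higher number from compound 1 to compound 2 (0.19 log units; within the scatter), so neither is ranked ahead of the other.

Compound 3 `COc1ccc(/C=C/c2nnc(-c3ccc4c(c3)OCCO4)o2)cc1` reads > 50000 nM, which is a limit of the assay and not a number.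

Its position relative to the other two rests on an at least 10-fold higher number from compound 1 to compound 3 (1.00 log units; beyond the scatter) and an at least 6.4-fold higher number from compound 2 to compound 3 (0.81 log units; beyond the scatter). From the compounds shown here alone, both steps are open-ended, so the true distance is unknown.

Compound 4 `C(=C/c1nnc(-c2ccc3c(c2)OCCO3)o1)\c1ccccc1` has not been measured. It differs from compound 3 by hydrogen in place of methoxy on an aromatic carbon, that is, 4-methoxyphenyl to phenyl: hydrogen in place of methoxy on an aromatic carbon.

Among the measured compounds shown here, no measured compound carries the plain phenyl, so the evidence is indirect. The nearest comparison is compound 1, which has fluoro where compound 3 has methoxy, and the change between them is an at least 10-fold higher number from compound 1 to compound 3 (1.00 log units; beyond the scatter). Compound 2, with 2-chlorophenyl, points the same way through an at least 6.4-fold higher number from compound 2 to compound 3 (0.81 log units; beyond the scatter). Among these three, only the 4-methoxyphenyl compound reaches the limit, so compound 4 is expected to sit nearer compound 1 and compound 2 than compound 3, though probably not fully level with them.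

The expected change is an at least 4.1-fold lower number from compound 3 to compound 4 (0.61 log units; beyond the scatter), towards a lower number in this assay.

Compound 4 is estimated at 12000 nM, with an expected range of 4000 nM to 40000 nM.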

Compound 4, half-maximal inhibitory concentration: > 50000 nM
Compound 4 gave a limit, no number; the forecaster's own chance of this, stated with the estimate: 20%; at least 4.1-fold (0.61 log units) between middle value and limit.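

In this assay, taking away the methoxy group does not bring a readable value: compound 4, with plain phenyl, stands at the assay limit just as compound 3 does. The measurable values now go with the fluoro and chloro substituents, since the phenyl compound lies clearly on the weaker side of both, with an at least 10-fold higher number from compound 1 to compound 4 (1.00 log units; beyond the scatter) and an at least 6.4-fold higher number from compound 2 to compound 4 (0.81 log units; beyond the scatter). The step between compound 3 and compound 4 cannot be read, because both compounds stand at the same limit: the limit of > 50000 nM in this assay, at which 2 of the 4 values shown sit.

From the compounds shown here alone, how far compound 3 and compound 4 lie apart beyond that limit remains unknown, so hydrogen and methoxy cannot be ranked at this position. The compounds shown also leave open whether a readable value needs fluoro or chloro specifically, or whether an amine, a nitrile or a carboxylic acid on the same aromatic carbon would also give one.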